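A few compounds are considered here, and "the series" means these few. Any claim that something is new, unique, unknown or untested is made for them only; others in the source may bear on it.

Among the measured compounds shown here, compound 1, `Cn1c(NN)nc(-c2ccccc2F)c(C#N)c1=O`, is one of two compounds measured in a functional assay on microsomes for inhibition, with a stated time of 1 h (a higher number here means a weaker inhibitor, a lower number a stronger inhibitor), where compound 1 gives 43 ug/mL. Compound 2, `Cn1c(NN)nc(-c2cccs2)c(C#N)c1=O`, gives 68 ug/mL in this assay. Compound 1 holds the lower of the two numbers, yet the gap between them sits within the usual scatter, so the two cannot be told apart. Compound 3, `Cn1c(NN)nc(-c2ccccc2Cl)c(C#N)c1=O`, differs from compound 1 by chloro in place of fluoro on an aromatic carbon. For the measured compounds named here, no measured pair shows what this change does, and the step of a 1.1-fold lower number from compound 1 to compound 3 (0.03 log units; within the scatter) is expected to be small, with no clear direction beyond the scatter. Compound 3 is therefore estimated at 40 ug/mL, within a range from 20 ug/mL to 85 ug/mL.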

Compound 3, half-maximal inhibitory concentration: 57 ug/mL
Compound 3: the middle estimate sits 1.4-fold (0.15 log units) below what was measured; measured number inside the range.
By their numbers in this assay, from the lowest: compounds 1, 3 and 2 (each within the scatter of the next).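

Among the compounds shown here, on this aromatic carbon, ortho to a large group, the first measured swap of one halogen for another gives a 1.3-fold higher number from compound 1 to compound 3 (0.12 log units; within the scatter) in this assay, so chloro and fluoro cannot be told apart here. The position therefore accepts either group without a change that rises above the scatter. No supporting data are available to explain this result. Still open, on these data alone, is whether a different kind of group on this carbon, such as an amine or a methoxy group, would move the number beyond the scatter.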